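Azetidinyl in place of anilino on a fused core

The compounds below may be only part of what the source reports. "The series", "measured", "known", "first", "only" and "open" are said of these compounds alone.

compound 1, `COc1ccc(NC2=CC(=O)c3c(nc4n3[C@H]3OC[C@@H](O)[C@H]3OC4)C2=O)cc1`, 2150 nM
compound 2, `CCCc1ccc(NC2=CC(=O)c3nc4n(c3C2=O)[C@H]2OC[C@@H](O)[C@H]2OC4)cc1`, 1560 nM
compound 3, `CCOc1ccc(NC2=CC(=O)c3nc4n(c3C2=O)[C@H]2OC[C@@H](O)[C@H]2OC4)cc1`, 1110 nM

In a functional assay on MGC-803 cells (Homo sapiens) for inhibition, read by sulforhodamine B assay (a higher number here means a weaker inhibitor, a lower number a stronger inhibitor), compound 1 gives 2150 nM, the highest of the three numbers, though compound 2 with 1560 nM and compound 3 with 1110 nM both lie within the scatter of it. Going by the values given here, the one measured step, a 1.4-fold lower number from compound 2 to compound 3 (0.15 log units; within the scatter), swaps one substituent on the aromatic ring for another and does not bear on the change to compound 4 `O=C1C(N2CCC2)=CC(=O)c2c1nc1n2[C@H]2OC[C@@H](O)[C@H]2OC1`, which is azetidin-1-yl in place of (4-methoxyphenyl)amino on a double-bonded ring carbon. The three measured compounds all keep that aromatic ring, so nothing in them tells how its removal acts. The expectation is therefore uncertain; compound 4 is estimated at 4500 nM, between 1000 nM and 20000 nM, and the expected step is a 2.1-fold higher number from compound 1 to compound 4 (0.32 log units; beyond the scatter), toward a higher number.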

Compound 4, half-maximal inhibitory concentration: > 16000 nM
Compound 4: no number, only a limit; the forecaster's own chance of this, stated with the estimate: 20%; middle value at least 3.5-fold (0.55 log units) away from the limit.
By their numbers in this assay, from the lowest: compounds 3, 2 and 1 (each within the scatter of the next). At a limit, above all of these: compound 4.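

Going by these compounds alone, on the double-bonded ring carbon, azetidin-1-yl in place of (4-methoxyphenyl)amino gives an at least 7.4-fold higher number from compound 1 to compound 4 (0.87 log units; beyond the scatter) in this assay, the only step here beyond the scatter. Within the data shown here, compound 1, compound 2 and compound 3 all keep the aromatic ring and lie within the scatter of one another, so only this change shows that the position does not accept every group. Compound 4 gives no number, only a limit: the limit of > 16000 nM in this assay, at which 1 of the 4 values shown sits.

Going by these compounds, what stays open is whether the loss of the aromatic ring or of the hydrogen-bond donor counts. A cyclohexylamino group at this carbon, which keeps the donor without the aromatic ring, would help to separate the two.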